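The compounds below may be only part of what the source reports. "The series", "measured", "known", "first", "only" and "open" are said of these compounds alone.

The compounds measured so far:

- compound 1 `CCc1ccc(C(Nc2ccccn2)c2ccc3cccnc3c2O)cc1`: 170 nM
- compound 2 `Cc1ccnc(NC(c2ccc3cccnc3c2O)c2c(Cl)cccc2Cl)c1`: > 40000 nM (a limit, not a number)
- compound 3 `Oc1cc2c(cc1C(c1ccc(F)cc1)N1CCCCC1)CCC2`: > 30000 nM (a limit, not a number)

All three were tested in an assay for inhibition of protein disulfide-isomerase (Homo sapiens), with a stated time of 1 h; a higher number here means a weaker inhibitor, a lower number a stronger inhibitor. Compound 1 is the only one of them for which an actual number was obtained: in this assay compound 1 gives 170 nM. For compound 2 this assay reports only a limit, > 40000 nM, so no number is known for it; (the limit of > 40000 nM in this assay, at which 1 of the 3 values shown sits). For compound 3 the result is likewise a limit, > 30000 nM; (the limit of > 30000 nM in this assay, at which 1 of the 3 values shown sits). For the measured compounds named here, compound 1 therefore stands alone as the single measured number among the three.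

Compound 4 `Cc1ccc(C(Nc2ccccn2)c2ccc3cccnc3c2O)cc1` has not yet been measured. It differs from compound 1 in one place: hydrogen in place of methyl on a saturated chain carbon bound to an aromatic carbon. Going by the values given here, no pair of measured compounds here differs in a single place, so no measured step shows what a change of this kind does in this assay. Since the change is small, the expected step is none beyond the usual scatter, in either direction: a 1.3-fold higher number from compound 1 to compound 4 (0.11 log units; within the scatter) is the step expected. Compound 4 is thus estimated at 220 nM in this assay, expected to fall between 80 nM and 600 nM.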

Compound 4, half-maximal inhibitory concentration: 460 nM
Compound 4: the middle estimate sits 2.1-fold (0.32 log units) below what was measured; the measured number falls inside the stated range.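

In this assay, for the compounds shown here, shortening 4-ethylphenyl to 4-methylphenyl gives a 2.7-fold higher number from compound 1 to compound 4 (0.43 log units; beyond the scatter), the first measured step here between compounds that differ in one place. This shows that the chain at this position is not interchangeable: losing a single carbon gives a weaker inhibitor, and the step, though modest, lies beyond the usual scatter. Nothing shown accounts for this loss, and the limits reported for the other compounds do not bear on it.

The compounds shown leave open whether a longer chain such as propyl, or a branched one such as isopropyl, would give a lower number than ethyl. They also leave open how a methoxy group at this position would compare, or an unsubstituted phenyl with no chain at all.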